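Swapping a Trifluoromethylsulfonyl for Trifluoromethoxy on a Bcl-2 Inhibitor

A few compounds are considered here, and "the series" means these few. Any claim that something is new, unique, unknown or untested is made for them only; others in the source may bear on it.

Compound 1, `CN(C)CC[C@H](CSc1ccccc1)Nc1ccc(S(=O)(=O)NC(=O)c2ccc(N3CCN(Cc4ccccc4-c4ccc(Cl)cc4)CC3)cc2)cc1S(C)(=O)=O`, in an assay on isolated protein for displacement of a labelled ligand from Apoptosis regulator Bcl-2 (Homo sapiens), read by fluorescence polarization (on this read-out higher numbers stand for weaker inhibition and lower numbers for stronger inhibition), gives < 1 nM, which is a limit of the assay and not a number.
Compound 2, `CN(C)CC[C@H](CSc1ccccc1)Nc1ccc(S(=O)(=O)NC(=O)c2ccc(N3CCN(Cc4ccccc4-c4ccc(Cl)cc4)CC3)cc2)cc1S(=O)(=O)C(F)(F)F`, in this assay gives < 1 nM, again a limit rather than a number.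

Both measured compounds therefore sit at the same boundary of what the assay can resolve: the limit of < 1 nM in this assay, at which 2 of the 2 values shown sit. Compound 2 stands at this limit, so its true inhibition constant is only known to lie somewhere beyond it. Within the data shown here, the one measured step, a step that the two limits leave unreadable from compound 1 to compound 2, cannot be read for the same reason, since both ends of it are limits.

Compound 3, `CN(C)CC[C@H](CSc1ccccc1)Nc1ccc(S(=O)(=O)NC(=O)c2ccc(N3CCN(Cc4ccccc4-c4ccc(Cl)cc4)CC3)cc2)cc1OC(F)(F)F`, carries a different change from compound 2: trifluoromethoxy in place of (trifluoromethyl)sulfonyl on an aromatic carbon. Among the measured compounds shown here, no measured step in this set touches this group, so the expectation rests only on the fact that two close relatives both lie at the limit. Compound 3 is therefore expected to remain very potent, with an estimate of 1.5 nM and a range from 0.3 nM to 8 nM. The expected step is an at least 1.5-fold higher number from compound 2 to compound 3 (0.17 log units; that floor lies within the scatter), which is within the usual scatter.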

Compound 3, inhibition constant: < 1 nM
Compound 3: a limit, no number (the forecaster's own chance of this, stated with the estimate: 45%); middle value at least 1.5-fold (0.17 log units) away from the limit.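

Compound 3 gives < 1 nM, which is a limit of the assay and not a number. No step among compound 1, compound 2 and compound 3 can be read, because all three stop at the same boundary: the limit of < 1 nM in this assay, at which 3 of the 3 values shown sit.

From the compounds shown here alone, whether methylsulfonyl, (trifluoromethyl)sulfonyl and trifluoromethoxy differ at all in this assay stays open.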